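The source may hold more compounds than are shown below. What is called first, only, known or untested is meant among the compounds shown, and "the series" means these compounds.

Compound 1 `CCCCCCCCCCN1NN=C(NC(=O)Nc2c(C(C)C)cccc2C(C)C)N1` gives 14 nM in an assay on microsomes from intestine for inhibition of acyl-CoA:cholesterol acyltransferase (Oryctolagus cuniculus); a lower number here means a stronger inhibitor, a higher number a weaker inhibitor. Within the data shown here, compound 2 `CCCCCCCCCCCCCCCCN1NN=C(NC(=O)Nc2c(C(C)C)cccc2C(C)C)N1` gives 57 nM in this assay, the higher of the two numbers measured so far, with a 4.1-fold higher number from compound 1 to compound 2 (0.61 log units; beyond the scatter) as the only step recorded. Compound 3 `COC(=O)CCCCCCCCCCN1NN=C(NC(=O)Nc2c(C(C)C)cccc2C(C)C)N1` is reached from compound 2 by methoxycarbonyl in place of hexyl on a saturated chain carbon, ten or more bonds along the chain from an amine nitrogen in a ring. Among the measured compounds shown here, the single step from compound 1 to compound 2 shows that lengthening the chain weakened inhibition, so trimming it back while closing it with an ester is expected to give a 2.3-fold lower number from compound 2 to compound 3 (0.36 log units; beyond the scatter). Compound 3 is therefore expected to show about 25 nM, within a range from 8 nM to 80 nM.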

Compound 3, half-maximal inhibitory concentration: 4700 nM
For compound 3 the middle estimate is 190-fold (2.27 log units) below the measured one; the measured number lies above the stated range.
By their numbers in this assay, from the lowest: compound 1; then compound 2; then compound 3.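

At this chain end, the kind of group matters far more than the added length seen so far. In this assay, methoxycarbonyl in place of hexyl gives an 82-fold higher number from compound 2 to compound 3 (1.92 log units; beyond the scatter), and methoxycarbonyl in place of hydrogen gives a 340-fold higher number from compound 1 to compound 3 (2.53 log units; beyond the scatter). Both steps are much larger than the one between the two plain chains, so this position accepts added hexyl far better than methoxycarbonyl.

Nothing available gives a reason for this loss of inhibition. On these data alone, whether a carboxylic acid or a primary amide in the same place would fare as poorly remains open.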